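The source may report more compounds than this note shows. Statements on the series, on what has been measured and on what is new or still open speak of the compounds shown alone.

Compound 1 `O=S(=O)(NCCNc1nccc(-c2c(-c3cccc(F)c3)nc3sccn23)n1)c1ccc(Br)cc1` and compound 2 `Cc1ccc(S(=O)(=O)NCCNc2nccc(-c3c(-c4cccc(F)c4)nc4sccn34)n2)cc1` share one core and differ only in the group carried by the sulfonyl-bearing ring. In a functional assay on SK-MEL-28 cells (Homo sapiens) for cytotoxicity, read by MTT assay (on this read-out higher numbers stand for weaker inhibition and lower numbers for stronger inhibition), compound 1 gives 13500 nM. Compound 2 reaches only the limit of this assay, > 20000 nM, a bound rather than a number. The step of an at least 1.4-fold higher number from compound 1 to compound 2 (0.17 log units; that floor lies within the scatter) therefore has a floor but no measured size; compound 2 stands at the limit of > 20000 nM in this assay, at which 1 of the 2 values shown sits. Compound 3 `O=S(=O)(NCCNc1nccc(-c2c(-c3cccc(F)c3)nc3sccn23)n1)c1ccc(C(F)(F)F)cc1` is not yet measured. It differs from compound 2 by trifluoromethyl in place of methyl on an aromatic carbon. Going by the values given here, the only measured step at this position is the one from compound 1 to compound 2, and that step shows no more than its floor, so no measured step sets the size or direction of the change to trifluoromethyl. Compound 3 is estimated to give about 20000 nM, within 7000 nM to 60000 nM. The step of a number no higher from compound 2 to compound 3 (the limit leaves the size open) is expected to be none beyond the scatter, with a fair chance that only a limit is reported again.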

Compound 3, half-maximal inhibitory concentration: 8450 nM
The estimate for compound 3 lay 2.4-fold (0.37 log units) above the measured number; measured number inside the range.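

In this assay this position now shows a step beyond the scatter, since trifluoromethyl in place of methyl on the aromatic carbon gives an at least 2.3-fold lower number from compound 2 to compound 3 (0.37 log units; beyond the scatter) as its reading. Trifluoromethyl and bromo cannot be told apart here, with a 1.6-fold lower number from compound 1 to compound 3 (0.20 log units; within the scatter) as the comparison between them, so the two groups sit together on one side of methyl in these three compounds. The size of the methyl step stays open, for compound 2 is a limit and not a number: the limit of > 20000 nM in this assay, at which 1 of the 3 values shown sits.

The values show that the group at this position matters, but they do not show why trifluoromethyl and methyl differ. The compounds shown also leave open how this position responds to a group of another kind, such as an amine, a carboxylic acid or a methoxy group.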